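This account rests on a few compounds, and the source may have more. Where it says the series, first, only, none or still open, it means among the compounds named here.

Going by the values given here, compound 1 `COc1ccc2c(=O)c(/C=C/C(=O)Nc3ccccc3Cl)coc2c1` carries the highest number of the three measured so far in a functional assay on HeLa cells (Homo sapiens) for inhibition, read by MTT assay, with a stated time of 48 h (on this read-out higher numbers stand for weaker inhibition and lower numbers for stronger inhibition), where compound 1 gives 22400 nM. Compound 2 `COc1cccc(NC(=O)/C=C/c2coc3cc(OC)ccc3c2=O)c1` gives 19200 nM and compound 3 `COc1ccc(NC(=O)/C=C/c2coc3cc(OC)ccc3c2=O)cc1` gives 13000 nM, and all three values lie within the scatter of one another, so no order among them is read. Each measured step exchanges the group on the amide-type nitrogen: a 1.2-fold lower number from compound 1 to compound 2 (0.07 log units; within the scatter), a 1.7-fold lower number from compound 1 to compound 3 (0.24 log units; within the scatter) and a 1.5-fold lower number from compound 2 to compound 3 (0.17 log units; within the scatter), none of them beyond the scatter.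

Compound 4 `COc1ccc2c(=O)c(/C=C/C(=O)NCc3ccc(C)cc3)coc2c1` is not yet measured. It differs from compound 1 by 4-methylbenzyl in place of 2-chlorophenyl on an amide-type nitrogen. Among the compounds with values here, the three measured steps bear on this only indirectly: each swapped one group for another on the same amide-type nitrogen and stayed within the scatter, but none introduced a 4-methylbenzyl, so the exact change has no measured precedent. On that basis the step from compound 1 to compound 4 is expected to fall within the scatter, with a range widened to allow for the untested kind of change.

The estimate for compound 4 in this assay is 18000 nM, with a range from 6000 nM to 50000 nM. The expected step is a 1.2-fold lower number from compound 1 to compound 4 (0.09 log units; within the scatter).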

Compound 4, half-maximal inhibitory concentration: > 100000 nM
Compound 4: a limit, no number; the forecaster's own chance of this, stated with the estimate: 10%; middle value at least 5.5-fold (0.74 log units) from the limit.
By their numbers in this assay, from the lowest: compounds 3, 2 and 1 (each within the scatter of the next). At a limit, above all of these: compound 4.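

In this assay, the reading for compound 4 is a limit and not a number: the limit of > 100000 nM in this assay, at which 1 of the 4 values shown sits. Placing 4-methylbenzyl on the amide-type nitrogen gives an at least 4.4-fold higher number from compound 1 to compound 4 (0.64 log units; beyond the scatter), an at least 7.6-fold higher number from compound 3 to compound 4 (0.88 log units; beyond the scatter) and an at least 5.2-fold higher number from compound 2 to compound 4 (0.71 log units; beyond the scatter), so this position is not indifferent to every exchange, although exchanges among 2-chlorophenyl, 3-methoxyphenyl and 4-methoxyphenyl stayed within the scatter. All three new steps lie beyond the scatter and set compound 4 apart from compounds 1, 2 and 3, but their full size cannot be read, as each rests on a limit.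

A plain benzyl or a 4-methylphenyl at this position would help show whether the shift goes with the benzyl part or with the methyl group. As far as these compounds go, how a longer chain such as 2-phenylethyl, or a chain ending in an amine, would read in this assay remains open.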